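Amide aryl variation in the Raji antiproliferative series

The compounds below may be only part of what the source reports. "The series", "measured", "known", "first", "only" and "open" are said of these compounds alone.

Measured so far:
- compound 1, `CN1CCN(c2ccc(Nc3nc(-c4cccc(NC(=O)c5ccc(C(F)(F)F)cc5)c4)sc3C(N)=O)cc2)CC1`: 91.9%
- compound 2, `CN1CCN(c2ccc(Nc3nc(-c4cccc(NC(=O)c5ccc(F)cc5)c4)sc3C(N)=O)cc2)CC1`: 95.3%
- compound 3, `CN1CCN(c2ccc(Nc3nc(-c4cccc(NC(=O)c5cccc(F)c5)c4)sc3C(N)=O)cc2)CC1`: 2.78%

All three share one core and differ only in the aryl group on the carbonyl carbon. In a functional assay on Raji cells (Homo sapiens) for antiproliferative activity, read by CCK-8 assay, with a stated time of 72 h, tested at 40 uM (on this read-out higher numbers stand for more inhibition at the one concentration tested (going by the name of the read-out) and lower numbers for less inhibition), compound 3 gives 2.78%, the lowest of the three numbers; the steps of a number 89.1 percentage points lower from compound 1 to compound 3 (beyond the scatter) and a number 92.5 percentage points lower from compound 2 to compound 3 (beyond the scatter) are both large and beyond the scatter, while a number 3.4 percentage points higher from compound 1 to compound 2 (within the scatter) lies within it. Compound 4, `CN1CCN(c2ccc(Nc3nc(-c4cccc(NC(=O)c5ccc(C(F)(F)F)cn5)c4)sc3C(N)=O)cc2)CC1`, is not yet measured. The change from compound 3 is 5-(trifluoromethyl)pyridin-2-yl in place of 3-fluorophenyl on a carbonyl carbon. For the measured compounds named here, no measured step covers a pyridinyl ring, so the expectation rests on the two steps into compound 3, which show that 3-fluorophenyl is the one group that loses nearly all inhibition while 4-(trifluoromethyl)phenyl and 4-fluorophenyl hold it. Compound 4 carries trifluoromethyl again and drops 3-fluorophenyl, so a large step back up is expected, a number 77.2 percentage points higher from compound 3 to compound 4 (beyond the scatter), with a wide range given the untested ring nitrogen. The estimate for compound 4 in this assay is 80%, between 40% and 97%.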

Compound 4, a percentage reported as inhibition, at one concentration (the size of the read-out at that concentration, not a potency): 84.6%
Compound 4: the middle estimate sits 4.6 percentage points below what was measured, and the stated range covers the measured number.
By their numbers in this assay, from the lowest: compound 3; then compounds 4, 1 and 2 (each within the scatter of the next, the first and the last beyond it).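

In this assay, a number 81.8 percentage points higher from compound 3 to compound 4 (beyond the scatter) shows that the carbonyl carbon accepts a ring with a nitrogen atom and that high inhibition is not confined to the phenyl groups of compound 1 and compound 2. For the compounds shown here, the replacement of 4-(trifluoromethyl)phenyl by 5-(trifluoromethyl)pyridin-2-yl gives a number 7.3 percentage points lower from compound 1 to compound 4 (within the scatter) and so leaves the number within the scatter, whereas the replacement of 4-fluorophenyl gives a number 10.7 percentage points lower from compound 2 to compound 4 (beyond the scatter) as a modest loss, so 3-fluorophenyl remains the only group here with almost no inhibition. No data given here account for that loss.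

Still open, on these data alone, is whether the loss follows the 3-fluoro substituent specifically, which 3-(trifluoromethyl)phenyl or 3-chlorophenyl would test. Also open, as far as these compounds go, is how an amine or a carboxylic acid on this aryl ring would read out, and these single-concentration numbers give no potency ranking.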